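The source may report more compounds than this note shows. Statements on the series, on what has been measured and on what is new or still open speak of the compounds shown alone.

Compound 1, `CCCCCCCCCCCCCCCCCCNC(=O)[C@H]1CSC(CCCCCCCCCCCC)N1`, is the reference point of this series. In a functional assay on RH7777 cells (Homo sapiens) for antiproliferative activity against RH7777 (Rattus norvegicus), read by sulforhodamine B assay (on this read-out lower numbers stand for stronger inhibition and higher numbers for weaker inhibition), compound 1 gives about 20000 nM. Among the compounds that returned an actual number, compound 1 and compound 3 sit within the scatter of each other, and the remaining value is only a limit. Compound 2, `CCCCCCCCCCCCCCCCCCNC(=O)[C@H]1CSC(C2CCCCC2)N1`, carries a cyclohexyl group on the saturated ring carbon of the shared core; in this assay compound 2 gives > 20000 nM, which is a limit of the assay and not a number. Compound 3, `CCCCCCCCCCCCCCCCCCNC(=O)[C@H]1CSC(c2ccc(F)cc2)N1`, carries a 4-fluorophenyl group at the same position, and in this assay compound 3 gives 17400 nM. The steps connecting these three are modest: a number no lower from compound 1 to compound 2 (the limit leaves the size open), a 1.1-fold lower number from compound 1 to compound 3 (0.06 log units; within the scatter) and an at least 1.1-fold lower number from compound 2 to compound 3 (0.06 log units; that floor lies within the scatter). The limit at the limit of > 20000 nM in this assay, at which 1 of the 3 values shown sits, leaves the first of these open in size.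

Compound 4, `CCCCCCCCCCCCCCCCCCNC(=O)[C@H]1CSC(c2ccc(Br)cc2)N1`, is the next compound in line, and its change from compound 1 is 4-bromophenyl in place of dodecyl on a saturated ring carbon. For the measured compounds named here, the closest precedent is the move to compound 3, where an aryl group replaced the dodecyl chain without moving the number beyond the scatter. The step of a 1.2-fold lower number from compound 1 to compound 4 (0.07 log units; within the scatter) is therefore expected to stay within the scatter, with no clear direction. Compound 4 is thus estimated at 17000 nM, with a range from 8500 nM to 34000 nM.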

Compound 4, half-maximal inhibitory concentration: > 20000 nM
Compound 4 ended at the assay's limit; the forecaster's own chance of this, stated with the estimate: 25%; at least 1.1-fold (0.07 log units) between middle value and limit.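

The exchange of bromo for fluoro on an aromatic carbon is the first change among these compounds made on the aryl group itself, and it gives an at least 1.1-fold higher number from compound 3 to compound 4 (0.06 log units; that floor lies within the scatter), so this floor does not separate the two halogens, although the limit leaves room for a larger true gap. The exchange of 4-bromophenyl for dodecyl on the saturated ring carbon gives a number no lower from compound 1 to compound 4 (the limit leaves the size open). The step from compound 2 to compound 4 cannot be read, since it joins two limits. The result for compound 4 is a limit and not a number, so a second group at this saturated ring carbon, like the cyclohexyl of compound 2, now ends without a measurable value in this assay: the limit of > 20000 nM in this assay, at which 2 of the 4 values shown sit.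

The compounds shown leave open whether any group at this position can produce a step beyond the scatter from compound 1, as every readable step so far stays within it. As far as these compounds go, whether an amine or a hydroxyl on the phenyl ring, or a carboxylic acid in place of the aryl group, would bring a readable number remains unknown here.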